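A few compounds are considered here, and "the series" means these few. Any claim that something is new, unique, unknown or untested is made for them only; others in the source may bear on it.

Compound 2 `COc1cc(-c2nn(-c3cccc(NC(=O)c4cccc(C(F)(F)F)c4)c3)cc2-c2ccncc2)ccc1Cl` was tested in a functional assay on SR cells (Homo sapiens) for inhibition, read by sulforhodamine B assay, with a stated time of 48 h; a lower number here means that less compound is tolerated, a higher number that more compound is tolerated. In this assay compound 2 reached only the limit of the assay, > 50000 nM, which is a bound rather than a measured number. Compound 1 `COc1cc(-c2nn(-c3cccc(NC(=O)Nc4cc(C(F)(F)F)cc(C(F)(F)F)c4)c3)cc2-c2ccncc2)ccc1Cl` likewise gave only the limit > 50000 nM. Both values sit at the limit of > 50000 nM in this assay, at which 2 of the 2 values shown sit, so compound 2 cannot be ranked against compound 1. Compound 3 `COc1cc(-c2nn(-c3cccc(NC(=O)Nc4ccc(Cl)c(Cl)c4)c3)cc2-c2ccncc2)ccc1Cl` differs from compound 2 in one place: (3,4-dichlorophenyl)amino in place of 3-(trifluoromethyl)phenyl on a carbonyl carbon. Among the compounds with values here, no measured step shows what such a change does here. Compound 3 is expected to sit at the limit as well, so the expected step of a number no higher from compound 2 to compound 3 (the limit leaves the size open) is none beyond the scatter. The estimate for compound 3 is 50000 nM, in the range 20000 nM to 100000 nM.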

Compound 3, concentration lethal to 50% of the cells: > 50000 nM
Compound 3 was reported as a limit; the forecaster's own chance of this, stated with the estimate: 70%; the middle value lies on the limit itself.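

Compound 3, like compound 2, gives only a limit, so no step can be read between them: the limit of > 50000 nM in this assay, at which 3 of the 3 values shown sit. The compounds shown leave open what true value each of the three has, and whether the swap on the carbonyl carbon changes it.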